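This account rests on a few compounds, and the source may have more. Where it says the series, first, only, none or still open, it means among the compounds named here.

Measured compounds:
compound 1 `Cn1ncc(Cl)c1-c1cc(C(=O)N[C@@H]2CN[C@H](CCN3CCC(O)CC3)C[C@H]2c2ccc(Cl)c(Cl)c2)oc1Cl` — 13700 nM
compound 2 `Cn1ncc(Cl)c1-c1cc(C(=O)N[C@@H]2CN[C@H](CCN3CCCC3)C[C@H]2c2ccc(Cl)c(Cl)c2)oc1Cl` — 1940 nM
compound 3 `Cn1ncc(Cl)c1-c1cc(C(=O)N[C@@H]2CN[C@H](CC(O)CO)C[C@H]2c2ccc(Cl)c(Cl)c2)oc1Cl` — 1110 nM

All three were read in a functional assay on HCT-116 cells (Homo sapiens) for antiproliferative activity, read by sulforhodamine B assay, with a stated time of 72 h; on this read-out lower numbers stand for stronger inhibition and higher numbers for weaker inhibition. Compound 3 gives the lowest number of the three, but its gap to compound 2 is within the scatter, so the two cannot be ordered; only compound 1 stands clearly apart, a 12-fold lower number from compound 1 to compound 3 (1.09 log units; beyond the scatter) and a 7.1-fold lower number from compound 1 to compound 2 (0.85 log units; beyond the scatter).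

Compound 4 `Cn1ncc(Cl)c1-c1cc(C(=O)N[C@@H]2CN[C@H](CCN3CCCCC3)C[C@H]2c2ccc(Cl)c(Cl)c2)oc1Cl` has not been measured. Relative to compound 3: (piperidin-1-yl)methyl in place of 1,2-dihydroxyethyl on a saturated chain carbon bound to a saturated ring carbon. The bearing steps are a 1.7-fold lower number from compound 2 to compound 3 (0.24 log units; within the scatter), since compound 2 also carries a nitrogen ring on that carbon, and the larger 12-fold lower number from compound 1 to compound 3 (1.09 log units; beyond the scatter), where the ring carries a hydroxyl that compound 4 lacks. The group entering compound 4 sits nearer to compound 2 than to compound 1, so a small rise, a 2.7-fold higher number from compound 3 to compound 4 (0.43 log units; beyond the scatter), is expected, with compound 4 estimated at 3000 nM (range 1000 nM to 9000 nM).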

Compound 4, half-maximal inhibitory concentration: 1020 nM
Compound 4: the middle estimate sits 2.9-fold (0.47 log units) above what was measured, within the range that was stated.
By their numbers in this assay, from the lowest: compounds 4, 3 and 2 (each within the scatter of the next); then compound 1.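

With 2,3-dihydroxypropyl or 2-(piperidin-1-yl)ethyl on the core, the numbers cannot be told apart (a 1.1-fold lower number from compound 3 to compound 4 (0.04 log units; within the scatter)), so this position tolerates both an open diol chain and a nitrogen ring. Ring size also gives no readable change (a 1.9-fold lower number from compound 2 to compound 4 (0.28 log units; within the scatter)), whereas hydrogen in place of the ring hydroxy group alone gives a large step (a 13-fold lower number from compound 1 to compound 4 (1.13 log units; beyond the scatter)), tying the weak number of compound 1 to that one hydroxy group. Nothing available explains this result.

On these data alone, whether a morpholine ring or a carboxylic acid on the same chain would read like compound 4 remains open.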